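Removing one fluoro from a diaryl urea kinase inhibitor

The compounds below may be only part of what the source reports. "The series", "measured", "known", "first", "only" and "open" are said of these compounds alone.

Compound 1 `CNc1cc(Oc2c(F)cc(NC(=O)Nc3cccc(C(F)(F)F)c3)cc2F)ncn1`: 20 nM
Compound 2 `CNc1cc(Oc2c(C)cc(NC(=O)Nc3cccc(C(F)(F)F)c3)cc2C)ncn1`: 25 nM
Compound 3 `CNc1nccc(Oc2ccc(NC(=O)Nc3cccc(C(F)(F)F)c3)cc2)n1`: 50 nM

In an assay on isolated protein for inhibition of serine/threonine-protein kinase TNNI3K (Homo sapiens) (a lower number here means a stronger inhibitor, a higher number a weaker inhibitor), compound 1 gives 20 nM, the lowest number among the three measured compounds. Compound 2 gives 25 nM, a gap that lies within the usual scatter, so the two cannot be ordered. Compound 3, with a different core, gives 50 nM, which lies beyond the scatter from compound 1.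

Compound 4 `CNc1cc(Oc2ccc(NC(=O)Nc3cccc(C(F)(F)F)c3)cc2F)ncn1` has not yet been measured. It differs from compound 1 in one place: hydrogen in place of fluoro on an aromatic carbon. Among the compounds with values here, no measured pair shows exactly this step. Given that compound 2, with methyl in place of fluoro on both positions, gives 25 nM, a step of no more than modest size toward a higher number is expected in this assay, a 1.5-fold higher number from compound 1 to compound 4 (0.18 log units; within the scatter). Compound 4 is estimated at 30 nM, in the range 12 nM to 75 nM.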

Compound 4, half-maximal inhibitory concentration: 25 nM
Compound 4: middle estimate off by 1.2-fold (0.08 log units), on the high side; low and high end bracket the measured number.
By their numbers in this assay, from the lowest: compounds 1, 2, 4 and 3 (each within the scatter of the next, the first and the last beyond it).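

In this assay hydrogen in place of fluoro, on the aromatic carbon ortho to a (6-(methylamino)pyrimidin-4-yl)oxy group, gives a 1.3-fold higher number from compound 1 to compound 4 (0.10 log units; within the scatter) for this single exchange. Within the data shown here, this is the first direct reading at this position, and it shows that this one fluoro can be exchanged for hydrogen without a difference that can be told from scatter. Nothing at hand explains this outcome.

The compounds shown leave open what hydrogen at the remaining fluoro position would give on the same core. They also leave open how a chloro, methoxy or amino group would read at this position.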